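This account rests on a few compounds, and the source may have more. Where it says the series, first, only, none or still open, it means among the compounds named here.

Measured compounds:
- compound 1, `O=C(Nc1ccc(Nc2ncnc3c2OCCN3)cc1)Nc1ccc(Cl)c(C(F)(F)F)c1` — 188 nM
- compound 2, `COc1cccc(NC(=O)Nc2ccc(Nc3ncnc4c3OCCN4)cc2)c1` — 5290 nM

Within the data shown here, in an assay on isolated protein for inhibition of proto-oncogene tyrosine-protein kinase receptor Ret variant V804M (Homo sapiens), read by 33P incorporation, with stated times of 15 min and 40 min (on this read-out lower numbers stand for stronger inhibition and higher numbers for weaker inhibition), compound 2 stands at the highest of the two numbers; the only other compound, compound 1, gives a far lower number, and that gap lies well beyond the usual scatter. Compound 3, `O=C(Nc1ccc(Nc2ncnc3c2OCCN3)cc1)Nc1cccs1`, differs from compound 2 in one place: thiophen-2-yl in place of 3-methoxyphenyl on an amide-type nitrogen. Among the measured compounds shown here, no pair of measured compounds shows this kind of exchange, so its effect is unknown here. For the measured compounds named here, the single comparison available, between compound 1 and compound 2, shows that the group on this amide-type nitrogen can move the number strongly. For compound 3 a small step, either none beyond the scatter or a modest rise toward weaker inhibition, is expected, giving an estimated step of a 1.3-fold higher number from compound 2 to compound 3 (0.12 log units; within the scatter). Compound 3 is therefore expected to give about 7000 nM, within a range of 1500 nM to 30000 nM.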

Compound 3, half-maximal inhibitory concentration: 8640 nM
The estimate for compound 3 lay 1.2-fold (0.09 log units) below the measured number; low and high end bracket the measured number.
By their numbers in this assay, from the lowest: compound 1; then compounds 2 and 3 (each within the scatter of the next).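

In this assay, thiophen-2-yl in place of 3-methoxyphenyl on the amide-type nitrogen gives a 1.6-fold higher number from compound 2 to compound 3 (0.21 log units; within the scatter). At this position, then, a five-membered aromatic ring with one hetero atom reads like a six-membered aromatic ring of carbon only, and neither group brings the number close to that of compound 1, at 188 nM. Nothing shown here bears on why these two groups read alike.

Going by these compounds, it remains open whether a pyridine ring, a cyclohexyl ring or a short alkyl chain on this nitrogen would also stay within the scatter of compound 2. On these data alone, it is equally open whether the chloro and trifluoromethyl groups of compound 1 would lower the number if they were placed on the thiophene ring.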